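A Second Chloro Group and the Expected Gain in Potency

The source may report more compounds than this note shows. Statements on the series, on what has been measured and on what is new or still open speak of the compounds shown alone.

Three compounds share a core carrying a benzyl group with a chloromethyl substituent, and all were tested in a functional assay on DU-145 cells (Homo sapiens) for cytotoxicity, read by sulforhodamine B assay, with a stated time of 48 h; a higher number here means a weaker inhibitor of growth, a lower number a stronger inhibitor of growth. Compound 1 `ClCc1ccccc1Cn1cnc2c(Cl)ncnc21` gives 34700 nM. Compound 2 `ClCc1cccc(Cn2cnc3ncnc(Cl)c32)c1` gives 30900 nM, the second highest of the three numbers; its nearest neighbour is compound 1, and those two values lie within the scatter of each other, so no order between them can be claimed. The furthest value belongs to compound 3 `ClCc1cccc(Cn2cnc3c(Cl)nc(Cl)nc32)c1`, which gives 2950 nM, a value well beyond the scatter from compound 2 in the direction of stronger growth inhibition. Compound 3 carries two chloro groups on the fused ring system where compound 2 carries one.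

Compound 4 `ClCc1cccc(Cn2cnc3nc(Cl)nc(Cl)c32)c1` has not yet been measured. It differs from compound 2 by chloro in place of hydrogen on an aromatic carbon. Within the data shown here, no direct step between two measured compounds mirrors this change, so the expectation rests on what the values of compound 2 and compound 3 show: a second chloro on the fused system accompanies a lower number. A step from compound 2 to compound 4 of roughly a 7.7-fold lower number from compound 2 to compound 4 (0.89 log units; beyond the scatter) is therefore expected, toward stronger inhibition and beyond the scatter. For compound 4 the value in this assay is estimated at 4000 nM, with a range from 1500 nM to 12000 nM.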

Compound 4, concentration for total growth inhibition: 260 nM
The estimate for compound 4 lay 15-fold (1.19 log units) above the measured number; the whole stated range lies above it.
By their numbers in this assay, from the lowest: compound 4; then compound 3; then compounds 2 and 1 (each within the scatter of the next).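

In this assay, the change of hydrogen to chloro on the aromatic carbon between two ring nitrogen atoms gives a 120-fold lower number from compound 2 to compound 4 (2.07 log units; beyond the scatter). Among these compounds, this is the only pair among the four compounds that differs in just one place, so it is the one comparison that ties a change in the number to a single site on the shared core. The step shows that this carbon is far from a silent spot in this series: a chloro group, 1 heavy atom with no ring, is enough to bring the value from compound 2 at 30900 nM to compound 4 at 260 nM in a large step for so small an edit.

The compounds shown leave open whether the gain belongs to chloro itself or would also appear with another group on this carbon, such as bromo, an amine or a methoxy group, and whether it would carry over to a core with the chloromethyl group placed as in compound 1. Nothing available here accounts for the size of this step.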